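A few compounds are considered here, and "the series" means these few. Any claim that something is new, unique, unknown or untested is made for them only; others in the source may bear on it.

Compound 1 `C=CC(=O)Nc1nc(-c2ccc(C(F)(F)F)cc2)cs1`: 4000 nM
Compound 2 `C=CC(=O)N(CC(=O)OC)c1nc(-c2ccccc2)cs1`: > 30000 nM (a limit)
Compound 3 `C=CC(=O)N(Cc1cc(C)no1)c1nc(-c2ccccc2)cs1`: > 30000 nM (a limit)

In a functional assay on HT-29 cells (Homo sapiens) for antiproliferative activity, read by MTT assay, with a stated time of 72 h (a lower number here means a stronger inhibitor, a higher number a weaker inhibitor), compound 3 has no exact number, only the limit > 30000 nM. Compound 2 also gives only a limit, and the overall picture is the limit of > 30000 nM in this assay, at which 2 of the 3 values shown sit.

Compound 4 `C=CC(=O)N(Cc1cc(C)no1)c1nc(-c2ccc(C(F)(F)F)cc2)cs1` is compound 3 with a single change: trifluoromethyl in place of hydrogen on an aromatic carbon. Among the measured compounds shown here, no measured step shows this change directly. For the measured compounds named here, the only measured step that reaches compound 3 is a step that the two limits leave unreadable from compound 2 to compound 3, so it offers no size to carry over.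

Going by the values given here, the one hint comes from compound 1, which also carries trifluoromethyl and gives a real number, 4000 nM. On that basis, a step towards a lower number, meaning stronger inhibition, is expected, although its size is poorly defined and compound 4 could still end up reported only as a limit. The expected change is an at least 3.0-fold lower number from compound 3 to compound 4 (0.47 log units; beyond the scatter). For compound 4 the estimated value is 10000 nM, with an expected range from 3000 nM to 30000 nM.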

Compound 4, half-maximal inhibitory concentration: 22300 nM
Estimate against measurement, compound 4: 2.2-fold (0.35 log units) below; low and high end bracket the measured number.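

In this assay, trifluoromethyl in place of hydrogen on the aromatic carbon gives an at least 1.3-fold lower number from compound 3 to compound 4 (0.12 log units; that floor lies within the scatter), so the change may strengthen inhibition, but only a floor for its size can be read. With trifluoromethyl present in both compounds, (3-methyl-1,2-oxazol-5-yl)methyl in place of the amide hydrogen gives a 5.6-fold higher number from compound 1 to compound 4 (0.75 log units; beyond the scatter), the first readable size for a group on that nitrogen, and it shows weaker inhibition. Compound 4 thus has an exact number, whereas the two other compounds with a group on that nitrogen have only a limit: the limit of > 30000 nM in this assay, at which 2 of the 4 values shown sit.

As far as these compounds go, it remains open how a chlorine atom or a methoxy group would compare with trifluoromethyl on the same aromatic carbon. Also open, from the compounds shown here alone, is what a plain methyl group on the amide nitrogen would do to the number.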